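The source may hold more compounds than are shown below. What is called first, only, known or untested is meant among the compounds shown, and "the series" means these compounds.

Measured in a functional assay (aorta) with Rattus norvegicus as the target; a higher number here means that more compound is needed for the effect, a lower number that less compound is needed:
Compound 1 `C/N=C(/S)C1=CC(C)(C(F)(F)F)Oc2ccc([N+](=O)[O-])cc21`: 0.302 nM
Compound 2 `CC1(C)C=C(C(=O)NCCC#N)c2cc([N+](=O)[O-])ccc2O1`: 2.82 nM
Compound 3 `CC1(CF)C=C(C(=O)NCCC#N)c2cc([N+](=O)[O-])ccc2O1`: 3.98 nM

Compound 3, at 3.98 nM, lies within the scatter of compound 2 and beyond the scatter of compound 1, whose number is lower. Compound 4 `CC1(C(F)(F)F)C=C(C(=O)NCCC#N)c2cc([N+](=O)[O-])ccc2O1` carries trifluoromethyl in place of fluoromethyl on a saturated ring carbon. Among the measured compounds shown here, compound 1 also carries trifluoromethyl, but it differs from compound 3 elsewhere too, so it isolates no step for this change. For the measured compounds named here, the one measured step that bears on it is a 1.4-fold higher number from compound 2 to compound 3 (0.15 log units; within the scatter), where fluoro replaces hydrogen on a saturated chain carbon. On that evidence, no step beyond the scatter is expected in this assay, in either direction. The estimated step is a 1.3-fold lower number from compound 3 to compound 4 (0.12 log units; within the scatter). Compound 4 is expected at 3 nM, with an estimated range of 0.9 nM to 12 nM.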

Compound 4, half-maximal effective concentration: 0.692 nM
Compound 4: the middle estimate sits 4.3-fold (0.64 log units) above what was measured; the measured number lies below the stated range.
By their numbers in this assay, from the lowest: compound 1; then compound 4; then compounds 2 and 3 (each within the scatter of the next).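

Among the compounds shown here, on the saturated ring carbon next to the ring oxygen, trifluoromethyl is the first change to pass the scatter in this assay, with a 5.8-fold lower number from compound 3 to compound 4 (0.76 log units; beyond the scatter) and a 4.1-fold lower number from compound 2 to compound 4 (0.61 log units; beyond the scatter). The single fluoro of compound 3 stayed within the scatter of compound 2, so among these compounds a clear shift at this position appears only with trifluoromethyl. With trifluoromethyl on that carbon, the group on the double-bonded ring carbon still matters, with a 2.3-fold higher number from compound 1 to compound 4 (0.36 log units; beyond the scatter).

Nothing available explains the size of these steps. As far as these compounds go, how difluoromethyl or an ethyl group would behave on this carbon remains open.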